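A few compounds are considered here, and "the series" means these few. Any claim that something is new, unique, unknown or untested is made for them only; others in the source may bear on it.

Measured so far in an assay on HEK293 cells for displacement of a labelled ligand from adenosine receptor A2b (Homo sapiens), read by radioligand binding, with a stated time of 30 min, tested at 1 uM; a lower number here means less inhibition, a higher number more inhibition at the concentration tested (going by the name of the read-out):
- compound 1, `CC1=C(C(=O)OC(C(F)(F)F)C(F)(F)F)C(c2ccsc2)NC(=O)N1`: 1%
- compound 2, `CC1=C(C(=O)OC(C(F)(F)F)C(F)(F)F)C(c2ccoc2)NC(=O)N1`: 2%
- compound 3, `CC1=C(C(=O)OC(C)C(F)(F)F)C(c2cccs2)NC(=O)N1`: 1%; 4% (2 entries)

For the measured compounds named here, compound 2 gives 2% in this assay, and the only measured step leading to it is a number 1 percentage points higher from compound 1 to compound 2 (within the scatter). Compound 3 has been measured more than once, and its entries sit at (the several entries of compound 3 in this assay, 1%; 4% (2 entries)), so every number seen here is small and none of the three compounds can be told apart.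

The change now considered is thiophen-2-yl in place of furan-3-yl on a saturated ring carbon, giving compound 4, `CC1=C(C(=O)OC(C(F)(F)F)C(F)(F)F)C(c2cccs2)NC(=O)N1`. Going by the values given here, the one measured step that touches a change of this kind, a swap of one five-membered aromatic ring for another on the same saturated ring carbon, is a number 1 percentage points higher from compound 1 to compound 2 (within the scatter), which lay within the scatter. Compound 3 carries the same thiophen-2-yl group as compound 4, though on a different ester, and its entries at the several entries of compound 3 in this assay, 1%; 4% (2 entries) are as low as those of compound 1 and compound 2. Among the compounds with values here, no measured step therefore points to a shift beyond the scatter, and compound 4 is expected to stay at the same low level, with an estimated step of no change at the digits printed from compound 2 to compound 4 (within the scatter). Compound 4 is thus estimated at 2%, expected to fall between 0% and 8%.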

Compound 4, a percentage reported as inhibition, at one concentration (the size of the read-out at that concentration, not a potency): 1%
For compound 4 the middle estimate is 1 percentage points above the measured one; the range from low to high includes it.
By their numbers in this assay, from the lowest: compounds 1, 4 and 2 (each within the scatter of the next).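

In this assay, placing thiophen-2-yl on the saturated ring carbon gives a number 1 percentage points lower from compound 2 to compound 4 (within the scatter), and no change at the digits printed from compound 1 to compound 4 (within the scatter). The earlier step only exchanged the ring sulfur for oxygen in a ring attached through its 3-position, whereas these two steps add a thiophene attached through its 2-position, so thiophen-3-yl, furan-3-yl and thiophen-2-yl on the same ester cannot be told apart at this position. A different ester with the same thiophen-2-yl group also stays at a similarly low level in the separate entries: the several entries of compound 3 in this assay, 1%; 4% (2 entries)

All these numbers are small, so the compounds shown offer no starting point for ranking groups at this position, and they leave open whether a larger or differently built group, such as phenyl or a ring carrying an amine or a carboxylic acid, would give a number beyond the scatter. On these data alone, each number also comes from a single tested concentration, so how these compounds would compare at a higher concentration remains open.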